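Nitro in Place of Chloro: Expected Growth Inhibition

The source may hold more compounds than are shown below. What is called first, only, known or untested is meant among the compounds shown, and "the series" means these compounds.

Compound 1, `CC1=CC[C@H](C(C)(C)NC(=S)N/N=C/c2ccccc2)CC1`: 22200 nM
Compound 2, `COc1ccc(/C=N/NC(=S)NC(C)(C)[C@H]2CC=C(C)CC2)cc1`: 33600 nM
Compound 3, `CC1=CC[C@H](C(C)(C)NC(=S)N/N=C/c2cccc(Cl)c2)CC1`: 53000 nM

Of the compounds shown here, three sharing one core have been tested in a functional assay on HT-29 cells (Homo sapiens) for inhibition, read by sulforhodamine B assay, with a stated time of 48 h; a lower number here means a stronger inhibitor of growth, a higher number a weaker inhibitor of growth. Compound 3 gives the highest number of the three. Its distance from compound 1 is modest, a 2.4-fold higher number from compound 1 to compound 3 (0.38 log units; beyond the scatter), while its distance from compound 2, a 1.6-fold higher number from compound 2 to compound 3 (0.20 log units; within the scatter), stays within the scatter of the method, so compound 3 and compound 2 cannot be told apart.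

Compound 4, `CC1=CC[C@H](C(C)(C)NC(=S)N/N=C/c2cccc([N+](=O)[O-])c2)CC1`, is not yet measured. It differs from compound 3 in one place: nitro in place of chloro on an aromatic carbon.

The steps measured so far all concern the same aromatic ring. The step of a 1.5-fold higher number from compound 1 to compound 2 (0.18 log units; within the scatter) lies within the scatter, and the step of a 2.4-fold higher number from compound 1 to compound 3 (0.38 log units; beyond the scatter) is modest. Both put a group where hydrogen stood; none exchanges one group for another, as the move to nitro does. Changes on this ring have so far shifted the number little, in the direction of a higher number or not at all. A similarly small step, without clear direction beyond the scatter, is therefore expected.

Compound 4 is expected to give about 55000 nM, with a range from 20000 nM to 150000 nM. This estimate means an expected step of a 1.0-fold higher number from compound 3 to compound 4 (0.02 log units; within the scatter).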

Compound 4, concentration for total growth inhibition: 21900 nM
Estimate against measurement, compound 4: 2.5-fold (0.40 log units) above; measured number inside the range.
By their numbers in this assay, from the lowest: compounds 4, 1, 2 and 3 (each within the scatter of the next, the first and the last beyond it).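

In this assay, among these compounds, nitro in place of chloro is the first exchange of one group for another on this aromatic carbon, meta to a large group, and it gives a step beyond the scatter, a 2.4-fold lower number from compound 3 to compound 4 (0.38 log units; beyond the scatter), so the identity of the group matters here and not only whether a group is present. Set against the hydrogen of compound 1, nitro gives a 1.0-fold lower number from compound 1 to compound 4 (0.01 log units; within the scatter), which lies within the scatter, whereas chloro in place of the same hydrogen gives a 2.4-fold higher number from compound 1 to compound 3 (0.38 log units; beyond the scatter), so among these compounds putting a group on this carbon does not by itself mean a higher number. Nothing available here explains why chloro and nitro part in this way.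

These compounds leave open whether an amine or a carboxylic acid on this same carbon would fall with nitro, level with hydrogen, or with chloro, beyond the scatter from it. They also leave open whether nitro on another carbon of the ring, or together with methoxy, would keep the number where compound 4 stands.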